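This account rests on a few compounds, and the source may have more. Where it says the series, first, only, none or still open, it means among the compounds named here.

Compound 2 `Nc1ccc(S(=O)(=O)N2CCN(c3ncc(C(O)(C(F)(F)F)C(F)(F)F)cc3C#CCO)CC2)cn1` shares its core with compound 1 `Nc1ccc(S(=O)(=O)N2CCN(c3ncc(C(O)(C(F)(F)F)C(F)(F)F)cc3C#CC3CC3)CC2)cn1` and compound 3 `CC(C)(C)n1cc(-c2cc(C(O)(C(F)(F)F)C(F)(F)F)cnc2N2CCN(S(=O)(=O)c3ccc(N)nc3)CC2)cn1`, differing only in the group on one aromatic carbon. In an ADME assay (liver) for metabolic stability, with Liver microsome (Homo sapiens) as the target, using microsomes and NADPH, with a stated time of 30 min, tested at 1 uM (on this read-out higher numbers stand for fast clearance and lower numbers for slow clearance), compound 2 gives < 14 mL.min-1.g-1, which is a limit of the assay rather than a number. Compound 1 likewise gives a limit, < 14 mL.min-1.g-1. Compound 3 gives 86 mL.min-1.g-1. The step that the two limits leave unreadable from compound 1 to compound 2 cannot be read, since both values sit at the limit of < 14 mL.min-1.g-1 in this assay, at which 2 of the 3 values shown sit. The step of an at least 6.1-fold higher number from compound 2 to compound 3 (0.78 log units; beyond the scatter), where the 1-(tert-butyl)-1H-pyrazol-4-yl group replaces the triple-bonded chain, is the one that bears on the new compound; so does an at least 6.1-fold higher number from compound 1 to compound 3 (0.78 log units; beyond the scatter), of the same size.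

Compound 4 `Nc1ccc(S(=O)(=O)N2CCN(c3ncc(C(O)(C(F)(F)F)C(F)(F)F)cc3-c3ccccc3O)CC2)cn1` is not yet measured. It differs from compound 2 by 2-hydroxyphenyl in place of 3-hydroxyprop-1-yn-1-yl on an aromatic carbon. Going by the values given here, as in compound 3, an aromatic ring enters in place of a triple-bonded chain, so a step upward in this assay is expected, though an estimate smaller than the one seen for compound 3, an at least 2.1-fold higher number from compound 2 to compound 4 (0.33 log units; beyond the scatter), seems reasonable. Compound 4 is therefore expected to give about 30 mL.min-1.g-1, between 10 mL.min-1.g-1 and 90 mL.min-1.g-1.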

Compound 4, intrinsic clearance in microsomes: 22 mL.min-1.g-1
For compound 4 the middle estimate is 1.4-fold (0.13 log units) above the measured one; measured number inside the range.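

In this assay, two aromatic groups on this carbon do not behave alike: 2-hydroxyphenyl in place of 1-(tert-butyl)-1H-pyrazol-4-yl gives a 3.9-fold lower number from compound 3 to compound 4 (0.59 log units; beyond the scatter), so bringing in an aromatic ring here does not by itself lead to a number as high as that of the pyrazole compound. Set against the two triple-bonded chains, the same 2-hydroxyphenyl group gives an at least 1.5-fold higher number from compound 2 to compound 4 (0.19 log units; that floor lies within the scatter) and an at least 1.5-fold higher number from compound 1 to compound 4 (0.19 log units; that floor lies within the scatter), so it cannot be said whether this ring raises the number over either chain. These two steps remain floors because compound 1 and compound 2 each sit at a limit of the assay: the limit of < 14 mL.min-1.g-1 in this assay, at which 2 of the 4 values shown sit.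

Still open is which part of each group accounts for the gap between the two aromatic groups: the hydroxyl of the 2-hydroxyphenyl group or the tert-butyl of the pyrazole. A plain phenyl or a 1-methyl-1H-pyrazol-4-yl group on this carbon would help separate the two.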